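Swapping the aryl group on the piperazine of compound 1

The source may report more compounds than this note shows. Statements on the series, on what has been measured and on what is new or still open speak of the compounds shown alone.

Measured compounds:
compound 1, `O=C1c2ccccc2S(=O)(=O)N1CCCCCCN1CCN(c2cccc(Cl)c2Cl)CC1`: 487 nM
compound 2, `O=C1c2ccccc2S(=O)(=O)N1CCCCCN1CCN(c2cccc3ccccc23)CC1`: 36 nM

Both compounds were tested in an assay on HEK293 cells for displacement of a labelled ligand from 5-hydroxytryptamine receptor 7 (Homo sapiens); on this read-out lower numbers stand for stronger inhibition and higher numbers for weaker inhibition. Compound 1 gives 487 nM and has the higher of the two numbers; compound 2 gives 36 nM, and the gap between them is beyond the usual scatter, so compound 2 is the stronger binder of the two.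

Compound 3, `O=C1c2ccccc2S(=O)(=O)N1CCCCCCN1CCN(c2ncccn2)CC1`, has not yet been measured. It differs from compound 1 in one place: pyrimidin-2-yl in place of 2,3-dichlorophenyl on an amine nitrogen in a ring. For the measured compounds named here, no step between measured compounds tells how this change plays out, since compound 2 differs from compound 1 in more than one place. Given that, the step is expected to be small, with compound 3 estimated to bind somewhat more weakly than compound 1, a step of a 1.6-fold higher number from compound 1 to compound 3 (0.22 log units; within the scatter). In this assay compound 3 is expected to give about 800 nM, within a range from 200 nM to 3000 nM.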

Compound 3, inhibition constant: 2520 nM
For compound 3 the middle estimate is 3.2-fold (0.50 log units) below the measured one; measured number inside the range.
By their numbers in this assay, from the lowest: compound 2; then compound 1; then compound 3.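

Putting pyrimidin-2-yl in place of 2,3-dichlorophenyl brings a 5.2-fold higher number from compound 1 to compound 3 (0.71 log units; beyond the scatter) in this assay with everything else in the molecule held the same. For the compounds shown here, this is the first clean reading of this position, and it shows that the group on this amine nitrogen in a ring does affect binding, which the earlier pair could not show since compound 2 differs from compound 1 in more than one place. The change replaces a carbon-only aromatic ring carrying two chlorines with a smaller ring holding two nitrogens, and nothing measured here explains the weaker binding.

As far as these compounds go, whether the ring nitrogens or the missing chlorines matter more stays open, and a plain phenyl or a pyridin-2-yl group at this position would help separate the two. Also open, from the compounds shown here alone, is whether the same swap would play out alike on a longer chain.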